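This account rests on a few compounds, and the source may have more. Where it says the series, first, only, none or still open, it means among the compounds named here.

Compound 1 `Cc1ccc(NC(=O)Nc2cc(-c3ccccc3C(=O)O)ccc2N(C)c2ccccc2C(C)(C)C)cc1` gives > 1000 nM in an assay on HeLa cells for inhibition of Indoleamine 2,3-dioxygenase 1 (Homo sapiens), with stated times of 1 h and 18 h; a lower number here means a stronger inhibitor, a higher number a weaker inhibitor.
Compound 2 `Cc1ccc(NC(=O)Nc2cc(-c3ccccc3C(=O)O)ccc2N2CCC[C@@H]3CCCC[C@@H]32)cc1` gives 159 nM.
Compound 3 `CCCCN(CCCC)c1ccc(-c2ccccc2C(=O)O)cc1NC(=O)Nc1ccc(C)cc1` gives 45 nM.

All three share one core and differ only in the amine group on it. For compound 1 the value > 1000 nM is a limit of this assay rather than a number, so compound 1 stands at the limit of > 1000 nM in this assay, at which 1 of the 3 values shown sits, and is the weakest of the three on the numbers shown. Compound 4 `Cc1ccc(NC(=O)Nc2cc(-c3ccccc3C(=O)O)ccc2N(CC(C)C)C(C)C)cc1` is not yet measured; it carries isobutyl(isopropyl)amino in place of methyl(2-(tert-butyl)phenyl)amino on an aromatic carbon. Among the compounds with values here, two measured steps bear on this. Replacing the same group by dibutylamino, another amine without a ring, gave an at least 22-fold lower number from compound 1 to compound 3 (1.34 log units; beyond the scatter), and replacing it by a ring-fused amine gave an at least 6.2-fold lower number from compound 1 to compound 2 (0.79 log units; beyond the scatter). Both changes lowered the number beyond the scatter, and the ring-free one did so most. The step to compound 4, which likewise removes the aromatic ring from the amine, is therefore expected to be large and downward, about an at least 16-fold lower number from compound 1 to compound 4 (1.22 log units; beyond the scatter). For compound 4 the estimate is 60 nM, expected to lie between 20 nM and 200 nM.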

Compound 4, half-maximal inhibitory concentration: 42 nM
For compound 4 the middle estimate is 1.4-fold (0.15 log units) above the measured one; the measured number falls inside the stated range.
By their numbers in this assay, from the lowest: compounds 4 and 3 (each within the scatter of the next); then compound 2. At a limit, above all of these: compound 1.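

Compound 1 stands at a limit of the assay, not at a number: the limit of > 1000 nM in this assay, at which 1 of the 4 values shown sits. Even so, replacing its amine with isobutyl(isopropyl)amino gives an at least 23-fold lower number from compound 1 to compound 4 (1.37 log units; beyond the scatter) in this assay, and the branched chains of compound 4 perform like the straight butyl chains of compound 3, with a 1.1-fold lower number from compound 3 to compound 4 (0.03 log units; within the scatter). Against the ring-fused amine the result is a 3.8-fold lower number from compound 2 to compound 4 (0.58 log units; beyond the scatter), so at this position two differently shaped ring-free amines now agree in this assay, ahead of the two ring-bearing amines.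

The compounds shown leave open whether a much smaller amine such as dimethylamino, or a simple unfused ring such as piperidine, would hold this level. They also leave open how a longer chain such as dihexylamino would fare on the same nitrogen.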